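Cytotoxicity Limits Across a Shared Core

The source may hold more compounds than are shown below. What is called first, only, known or untested is meant among the compounds shown, and "the series" means these compounds.

Compound 1 `O=[N+]([O-])c1cn2c(n1)OC[C@@H](OCc1ccc(-c3ccc(OC(F)(F)F)cc3)cc1)C2`: > 128000 nM
Compound 2 `O=[N+]([O-])c1cn2c(n1)OC[C@@H](OCc1cccc(-c3ccc(C(F)(F)F)cc3)c1)C2`: > 128000 nM
Compound 3 `O=[N+]([O-])c1cn2c(n1)OC[C@@H](OCc1cccc(-c3ccc(F)cc3)c1)C2`: > 128000 nM

Each of these values in an ADME assay on Vero cells (Chlorocebus sabaeus) for cytotoxicity, with a stated time of 72 h (a higher number here means a weaker inhibitor, a lower number a stronger inhibitor), is a limit of the assay, not a number. Compound 2 therefore stands at the same limit as the other two, and no order among them can be read. Going by the values given here, the one measured step, a step that the two limits leave unreadable from compound 2 to compound 3, is likewise unreadable between its two limits.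

Compound 4 `COc1ccc(-c2cccc(CO[C@@H]3COc4nc([N+](=O)[O-])cn4C3)c2)cc1F` differs from compound 2 by 3-fluoro-4-methoxyphenyl in place of 4-(trifluoromethyl)phenyl on an aromatic carbon. Among the compounds with values here, no measured step bears directly on this change; the only evidence is the limit of > 128000 nM in this assay, at which 3 of the 3 values shown sit. No step beyond the scatter is therefore expected in this assay, and compound 4 is expected to reach the same limit. The estimate for compound 4 is 128000 nM, with a range from 64000 nM to 256000 nM. The expected step is a number no higher from compound 2 to compound 4 (the limit leaves the size open).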

Compound 4, half-maximal inhibitory concentration: > 128000 nM
Compound 4: no number, only a limit (the forecaster's own chance of this, stated with the estimate: 85%); the middle value lies on the limit itself.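

In this assay, going by these compounds alone, compound 4 gives > 128000 nM, a limit of the assay and not a number, so no step from compound 2 or compound 3 to it can be read. The compounds shown leave open whether changing these aryl groups alters cytotoxicity at all.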